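From methoxy to ethoxy at the assay limit

The compounds below may be only part of what the source reports. "The series", "measured", "known", "first", "only" and "open" are said of these compounds alone.

Measured in a functional assay on MDA-MB-231 cells (Homo sapiens) for inhibition, read by MTT assay, with a stated time of 72 h; a lower number here means a stronger inhibitor, a higher number a weaker inhibitor:
compound 1 `CN(C)c1ccc(-c2cc(C(=O)N3CCC4(CC3)CC(=O)c3nn(C(C)(C)C)cc3O4)c3ccccc3n2)cc1`: > 10000 nM, a limit
compound 2 `COc1cc(C(=O)N2CCC3(CC2)CC(=O)c2nn(C(C)(C)C)cc2O3)c2ccccc2n1`: > 10000 nM, a limit

Compound 2 has no number, only the limit > 10000 nM. Within the data shown here, the one measured step, a step that the two limits leave unreadable from compound 1 to compound 2, therefore has no readable size. What bears on the next step is the limit of > 10000 nM in this assay, at which 2 of the 2 values shown sit.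

Compound 3 `CCOc1cc(C(=O)N2CCC3(CC2)CC(=O)c2nn(C(C)(C)C)cc2O3)c2ccccc2n1` differs through (methyl in place of hydrogen on a saturated chain carbon bound to an oxygen on an aromatic ring), turning methoxy into ethoxy. With compound 2 held at > 10000 nM, no step beyond the scatter is expected in this assay. The expected change is a step that the limit leaves unreadable from compound 2 to compound 3. For compound 3 the estimate is 15000 nM, within an expected range of 6000 nM to 40000 nM.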

Compound 3, half-maximal inhibitory concentration: > 10000 nM
Compound 3 gave a limit, no number; the forecaster's own chance of this, stated with the estimate: 85%; the middle value does not contradict the limit.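

Compound 3 gives only the limit > 10000 nM and, like compound 1 and compound 2, offers no number, so no step among them can be read: the limit of > 10000 nM in this assay, at which 3 of the 3 values shown sit.

The compounds shown leave open whether any group on that aromatic carbon would give a number instead of a limit.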